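The source may hold more compounds than are shown below. What is called first, only, known or untested is meant among the compounds shown, and "the series" means these compounds.

Measured compounds:
Compound 1 `COc1ccc2[nH]c(C(=O)N3CC(=O)N(Cc4ccccc4)[C@@H](CCc4ccccc4)C3)cc2c1` — 4400 nM
Compound 2 `COc1cccc(CN2C(=O)CN(C(=O)c3cc4cc(OC)ccc4[nH]3)C[C@@H]2c2ccccc2)c1` — 13600 nM

Both values come from a physicochemical assay for solubility, read by spectrophotometry, in phosphate buffer, with a stated time of 2 h, at pH 7.4; a lower number here means a less soluble compound, a higher number a more soluble compound. Compound 1 has the lowest of the two numbers; compound 2 sits higher by a gap that lies beyond the usual scatter of repeated measurements, so compound 1 is the less soluble of the pair on this evidence.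

Compound 3 `COc1ccc2[nH]c(C(=O)N3CC(=O)N(Cc4ccccc4)[C@@H](CN4C(=O)c5ccccc5C4=O)C3)cc2c1` has not yet been measured in this assay. It differs from compound 1 in a single place: a group of 11 heavy atoms (8 carbon, 1 nitrogen, 2 oxygen; one five-membered non-aromatic ring with 1 hetero atom, one six-membered aromatic ring of carbon only) in place of a group of 7 heavy atoms (7 carbon; one six-membered aromatic ring of carbon only), on a saturated chain carbon bound to a saturated ring carbon The group that enters is larger and carries two hydrogen-bond acceptors where the benzyl group carried none.

Going by the values given here, no step between measured compounds resembles this change, so no measured analogue guides the direction. The step from compound 1 to compound 3 is expected to stay within the scatter, with at most a small move toward a lower number: a 1.3-fold lower number from compound 1 to compound 3 (0.10 log units; within the scatter). Compound 3 is therefore estimated at 3500 nM, with a range from 1200 nM to 10000 nM.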

Compound 3, solubility: > 100000 nM
Compound 3: no number, only a limit (the forecaster's own chance of this, stated with the estimate: 5%); middle value at least 28-fold (1.45 log units) away from the limit.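

In this assay, the read-out at this place, a saturated chain carbon bound to a saturated ring carbon, proves far from silent: replacing benzyl with the larger group that carries 2 hydrogen-bond acceptors gives an at least 22-fold higher number from compound 1 to compound 3 (1.35 log units; beyond the scatter). Compound 3 reaches the top of the range and carries a limit rather than a number: the limit of > 100000 nM in this assay, at which 1 of the 3 values shown sits. As far as these compounds go, the step is therefore a lower bound, and its true size stays unknown.

The compounds shown cannot tell which part of the entering group matters, the carbonyl groups or the ring as a whole, since both enter together in this single change. From the compounds shown here alone, it also remains open whether a much smaller group at this place, such as a simple amine or a carboxylic acid, would move the read-out as far.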